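Series notes: aryl ether swap on compound 1

This account rests on a few compounds, and the source may have more. Where it says the series, first, only, none or still open, it means among the compounds named here.

compound 1 `CN(Cc1ccc(OCCCNC(=N)N)cc1)c1nc2ccc(Oc3ccc(F)cc3)cc2s1`: 521000 nM
compound 2 `CN(Cc1ccc(OCCCN)cc1)c1nc2ccc(Oc3ccc(F)cc3)cc2s1`: 492000 nM
compound 3 `N=C(N)NCCCOc1ccc(CNc2nc3ccc(Oc4ccc(F)cc4)cc3s2)cc1`: 288000 nM

In an assay on cells for inhibition of Voltage-dependent T-type calcium channel subunit alpha-1H (Homo sapiens), read by FLIPR and calcium flux, with stated times of 600 s and 300 s (on this read-out lower numbers stand for stronger inhibition and higher numbers for weaker inhibition), compound 1 gives the highest of the three numbers, but the two steps away from it, a 1.1-fold lower number from compound 1 to compound 2 (0.02 log units; within the scatter) and a 1.8-fold lower number from compound 1 to compound 3 (0.26 log units; within the scatter), both lie within the scatter, so no order among the three can be read.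

Compound 4 `CN(Cc1ccc(OCCCNC(=N)N)cc1)c1nc2ccc(Oc3cccc(C(F)(F)F)c3)cc2s1` differs from compound 1 by 3-(trifluoromethyl)phenyl in place of 4-fluorophenyl on an oxygen on an aromatic ring. Neither measured step touches the aryl ether end: one removes a group from the amine nitrogen, the other a methyl from the core nitrogen, and both stayed within the scatter. Nothing measured therefore speaks to this change, and no step beyond the scatter is expected in this assay.

Compound 4 is expected to give about 500000 nM, ranging from 150000 nM to 1500000 nM. The expected step is a 1.0-fold lower number from compound 1 to compound 4 (0.02 log units; within the scatter).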

Compound 4, half-maximal inhibitory concentration: 771000 nM
The estimate for compound 4 lay 1.5-fold (0.19 log units) below the measured number; low and high end bracket the measured number.
By their numbers in this assay, from the lowest: compounds 3, 2, 1 and 4 (each within the scatter of the next, the first and the last beyond it).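

The aryl ether end now has a measured step of its own: in this assay, 3-(trifluoromethyl)phenyl in place of 4-fluorophenyl on this oxygen gives a 1.5-fold higher number from compound 1 to compound 4 (0.17 log units; within the scatter). This exchange of one aromatic ring for another, with more heavy atoms in the group that enters, therefore stays within the scatter, as the two earlier steps did. No supporting data bear on this result.

On these data alone, whether an amine or a carboxylic acid on this ring would give a step beyond the scatter remains open. Also open, as far as these compounds go, is whether the same swap behaves alike on compound 2 and compound 3.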